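Removing the Methyl from the Acrylic Acid of Compound 2

This account rests on a few compounds, and the source may have more. Where it says the series, first, only, none or still open, it means among the compounds named here.

Among the measured compounds shown here, compound 2 `C/C(=C\c1ccc(C(=O)c2ccc3c(c2)C(C)(C)CCC3(C)C)cc1)C(=O)O` gives 65% in a functional assay for activation of retinoic acid receptor gamma (Homo sapiens) (a higher number here means a larger maximal response, a lower number a smaller maximal response), the lower of the two numbers measured so far; the nearest neighbour, compound 1 `CC1(C)CCC(C)(C)c2cc(C(=O)c3ccc(/C=C/C(=O)O)cc3)ccc21`, reaches 86%. Compound 3 `CC1(C)CCC(C)(C)c2cc(C(=O)c3ccc(/C=C\C(=O)O)cc3)ccc21` takes the next step: 2-carboxyethenyl in place of 2-carboxyprop-1-en-1-yl on an aromatic carbon. For the measured compounds named here, the only measured step that bears on this is the reverse change, a number 21 percentage points lower from compound 1 to compound 2 (beyond the scatter). Undoing it would point upward by a comparable amount, although compound 3 does not simply reproduce compound 1. An increase is therefore expected, amounting to a number 11 percentage points higher from compound 2 to compound 3 (beyond the scatter). Compound 3 is estimated at 76%, with a range from 52% to 96%.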

Compound 3, largest response reached (reported as maximum), in percent of the reference or control that the assay uses: 46%
For compound 3 the middle estimate is 30 percentage points above the measured one; the measured number lies below the stated range.
By their numbers in this assay, from the lowest: compound 3; then compound 2; then compound 1.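

In this assay the removal of the methyl did not raise the response, giving a number 19 percentage points lower from compound 2 to compound 3 (beyond the scatter), so at this position the methyl cannot be judged apart from the geometry of the double bond. The configuration alone carries a large step, a number 40 percentage points lower from compound 1 to compound 3 (beyond the scatter), which exceeds the modest one seen earlier for adding the methyl. That comparison isolates the double bond as the sole change: the fact that compounds 1 and 3 differ only in the configuration as drawn

The compounds shown leave open how the response changes when the unsaturated chain gives way to a saturated propanoic acid chain. Also open, on these data alone, is whether an amide could stand in place of the carboxylic acid.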